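A few compounds are considered here, and "the series" means these few. Any claim that something is new, unique, unknown or untested is made for them only; others in the source may bear on it.

Measured so far: compound 1 `COc1ccc(-c2nc(/N=C(\N)NC(C)C)sc2-c2ccc(OC)cc2)cc1`, compound 2 `CNC(=O)NCc1nc(-c2ccc(OC)cc2)c(-c2ccc(OC)cc2)s1`.

In a functional assay with Oryctolagus cuniculus as the target (a higher number here means a weaker inhibitor, a lower number a stronger inhibitor), compound 1 gives only a limit, > 100 nM. In this assay, among the compounds with values here, compound 2 gives 22 nM, the only number. Between them lies an at least 4.5-fold lower number from compound 1 to compound 2 (0.65 log units; beyond the scatter); the limit of compound 1 is recorded as the limit of > 100 nM in this assay, at which 1 of the 2 values shown sits, so the true size of that step is not known beyond its floor.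

Compound 3 `COc1ccc(-c2nc(CCC(=O)O)sc2-c2ccc(OC)cc2)cc1` is not yet measured. Against compound 2 it carries carboxymethyl in place of (methylcarbamoyl)amino on a saturated chain carbon bound to an aromatic carbon. Within the data shown here, the one measured step, from compound 1 to compound 2, exchanged one chain group on the shared core for another and gave a stronger inhibitor; it says nothing direct about a carboxymethyl group in place of (methylcarbamoyl)amino. Among the measured compounds shown here, with no step of the same kind, the expected step of a 2.7-fold higher number from compound 2 to compound 3 (0.44 log units; beyond the scatter) is set near no change, and compound 3 is estimated at 60 nM with a range of 15 nM to 300 nM.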

Compound 3, half-maximal inhibitory concentration: < 100 nM
Compound 3: no number, only a limit; the forecaster's own chance of this, stated with the estimate: 20%; the middle value is on the limit's open side.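

In this assay compound 3 gives only a limit, < 100 nM. The 2-carboxyethyl chain, which carries no nitrogen, gives a number no higher from compound 1 to compound 3 (the limit leaves the size open) and so the (methylcarbamoyl)amino group of compound 2 is not the only chain end compatible with a number on this side of the limit. The sizes of the steps to compound 3 from compound 2 and from compound 1 cannot be read: the limit of < 100 nM in this assay, at which 1 of the 3 values shown sits.

On these data alone, whether compound 3 matches compound 2 or differs from it beyond the scatter remains open. Also open, as far as these compounds go, is how a methyl ester or a primary amine at the end of this chain, or a longer chain ending in the same carboxylic acid, would behave in this assay.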